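Purine series: dichloro to monochloro on the fused core

The source may hold more compounds than are shown below. What is called first, only, known or untested is meant among the compounds shown, and "the series" means these compounds.

Measured in a functional assay on UACC-62 cells (Homo sapiens) for cytotoxicity, read by sulforhodamine B assay, with a stated time of 48 h; a higher number here means a weaker inhibitor of growth, a lower number a stronger inhibitor of growth:
compound 1 `ClCc1ccc(Cn2cnc3c(Cl)ncnc32)cc1`: 33900 nM
compound 2 `ClCc1ccc(Cn2cnc3nc(Cl)nc(Cl)c32)cc1`: 3160 nM

Compound 2 gives the lowest number of the two; compound 1 sits well beyond the scatter from it. Compound 3 `ClCc1ccc(Cn2cnc3ncnc(Cl)c32)cc1` is not yet measured. From compound 2 to compound 3: hydrogen in place of chloro on an aromatic carbon. Among the compounds with values here, no step between measured compounds covers this change, so the expectation rests on compound 2 alone. A step toward a higher number is expected, moving compound 3 part of the way toward compound 1, as a 3.2-fold higher number from compound 2 to compound 3 (0.50 log units; beyond the scatter). Compound 3 is therefore estimated at 10000 nM, within 3000 nM to 40000 nM.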

Compound 3, concentration for total growth inhibition: 12000 nM
Compound 3: middle estimate off by 1.2-fold (0.08 log units), on the low side, and the stated range covers the measured number.
By their numbers in this assay, from the lowest: compound 2; then compound 3; then compound 1.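

Within the data shown here, this is the first step that changes one place only. Taking away the chloro group between two ring nitrogen atoms, with the other chloro group left in place, gives a 3.8-fold higher number from compound 2 to compound 3 (0.58 log units; beyond the scatter) and so a modest loss of growth inhibition. This position therefore affects the read-out, and chloro here outperforms hydrogen, though a single pair cannot show how general that is.

On these data alone, whether an amine, a methoxy group or fluoro at this position would match chloro remains open. No data at hand bear on why the step goes in this direction.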